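Shortening the amine chain of compound 3

A few compounds are considered here, and "the series" means these few. Any claim that something is new, unique, unknown or untested is made for them only; others in the source may bear on it.

In a functional assay on A549 cells (Homo sapiens) for antiproliferative activity, read by MTT assay, with a stated time of 72 h (on this read-out higher numbers stand for weaker inhibition and lower numbers for stronger inhibition), compound 1 (`COc1cc(N(C)CCN(C)C)c(NC(=O)c2ccnc(O)c2)cc1Nc1nccc(-c2cn(C)c3ccccc23)n1`) gives 11200 nM, while compound 2 (`COc1cc(N(C)CCN(C)C)c(NC(=O)c2cnccn2)cc1Nc1nccc(-c2cn(C)c3ccccc23)n1`) gives 4330 nM and compound 3 (`COc1cc(N(C)CCN(C)C)c(NC(=O)c2ncccn2)cc1Nc1nccc(-c2cn(C)c3ccccc23)n1`) gives 2490 nM on the same scale. Compound 3 thus shares the low end of this small set with compound 2. The step of a 1.7-fold lower number from compound 2 to compound 3 (0.24 log units; within the scatter) stays within the scatter, whereas a 2.6-fold lower number from compound 1 to compound 2 (0.41 log units; beyond the scatter) and a 4.5-fold lower number from compound 1 to compound 3 (0.65 log units; beyond the scatter) lie beyond it.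

Compound 4 (`COc1cc(N(C)C)c(NC(=O)c2ncccn2)cc1Nc1nccc(-c2cn(C)c3ccccc23)n1`) carries dimethylamino where compound 3 has (2-(dimethylamino)ethyl)(methyl)amino (hydrogen in place of (dimethylamino)methyl on a saturated chain carbon bound to a nitrogen on an aromatic ring). For the measured compounds named here, none of the measured steps touches this place. All three swap the group on a carbonyl carbon, so they offer only a rough sense of size, and that size is modest. Going by the values given here, no measured pair shows the direction, so a move toward a higher number, meaning weaker inhibition, is only a cautious expectation. The expected change is a 2.0-fold higher number from compound 3 to compound 4 (0.30 log units; within the scatter) in this assay as a modest one. For compound 4 the estimate is 5000 nM (1800 nM to 14000 nM).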

Compound 4, half-maximal inhibitory concentration: 8640 nM
Beside the measured number, compound 4's estimate is 1.7-fold (0.24 log units) below it; low and high end bracket the measured number.
By their numbers in this assay, from the lowest: compounds 3, 2, 4 and 1 (each within the scatter of the next, the first and the last beyond it).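

In this assay, for the compounds shown here, the earlier compounds varied only the group on the carbonyl carbon, so they said nothing about the amine chain. Replacing (2-(dimethylamino)ethyl)(methyl)amino with dimethylamino now gives this place a measured direction and size, a 3.5-fold higher number from compound 3 to compound 4 (0.54 log units; beyond the scatter), a step toward weaker inhibition that lies beyond the scatter. Nothing given here accounts for this loss of the (dimethylamino)methyl group.

The compounds shown leave open whether the outcome follows the terminal amine or the chain length, a question that a 2-methoxyethyl group, a longer chain such as 3-(dimethylamino)propyl, or a cyclic amine such as 4-methylpiperazin-1-yl at this place would address. They also leave open whether the same shortening has a similar effect when pyrazin-2-yl sits on the carbonyl carbon.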